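Rearranging an Ether Side Chain on a Fused Core

The compounds below may be only part of what the source reports. "The series", "measured", "known", "first", "only" and "open" are said of these compounds alone.

Measured so far:
- compound 1, `COCc1nc2nc(C)cc(Nc3ccc(S(F)(F)(F)(F)F)cc3)n2n1`: 2.8
- compound 2, `COCc1nc2nc(C)cc(Nc3ccc(C(F)(F)F)cc3)n2n1`: 2.5
- compound 3, `CCc1nc2nc(C)cc(Nc3ccc(C(F)(F)F)cc3)n2n1`: 3

In a physicochemical assay for lipophilicity, at pH 7.4 (on this read-out lower numbers stand for lower lipophilicity and higher numbers for higher lipophilicity), compound 1 stands second highest of the three: its nearest neighbour is compound 3, a number 0.30 log units lower from compound 1 to compound 2 (within the scatter) separates it from compound 2, and both gaps lie within the scatter. The unmeasured compound 4, `CCOc1nc2nc(C)cc(Nc3ccc(S(F)(F)(F)(F)F)cc3)n2n1`, keeps every atom of compound 1 but joins them differently: ethoxy in place of methoxymethyl on an aromatic carbon.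

Among the compounds with values here, no measured step matches this change. The closest is a number 0.50 log units higher from compound 2 to compound 3 (beyond the scatter), which touches the same side chain but removes the oxygen rather than moving it; the swap a number 0.30 log units lower from compound 1 to compound 2 (within the scatter) sits on the other end of the molecule and lies within the scatter. Moving the oxygen onto the aromatic carbon is therefore expected to shift this assay only slightly, if at all, with an upward lean. For compound 4 the estimate is 3.1, between 2.7 and 3.5, meaning an expected step of a number 0.30 log units higher from compound 1 to compound 4 (within the scatter).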

Compound 4, distribution coefficient: 3.4
Beside the measured number, compound 4's estimate is 0.30 log units below it, and the stated range covers the measured number.
By their numbers in this assay, from the lowest: compounds 2, 1 and 3 (each within the scatter of the next, the first and the last beyond it); then compound 4.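

Ethoxy in place of methoxymethyl gives a number 0.60 log units higher from compound 1 to compound 4 (beyond the scatter) in this assay, even though the two groups have the same heavy-atom count and the same single hydrogen-bond acceptor, so on this aromatic carbon those counts alone do not fix the number. The earlier side-chain step, a number 0.50 log units higher from compound 2 to compound 3 (beyond the scatter), took the oxygen out of the chain, and so it could not show that joining the same atoms differently also gives a step beyond the scatter. No measurement here accounts for the size or direction of this new step.

On these data alone, whether an amine or a longer chain such as propoxy on the same aromatic carbon would stay close to ethoxy remains open. So does whether the same swap of ethoxy for methoxymethyl gives a similar step when trifluoromethyl stands at the other end of the molecule.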